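Acrylamide warhead variants on a shared anilinopyrimidine core

The compounds below may be only part of what the source reports. "The series", "measured", "known", "first", "only" and "open" are said of these compounds alone.

Measured compounds:
- compound 1 `C=C(Cl)C(=O)Nc1cc(Nc2nccc(-c3cn(C)c4ccccc34)n2)c(OC)cc1N(C)CCN(C)C` gives 1290 nM in a functional assay on NCI-H1975 cells (Homo sapiens) for antiproliferative activity, read by MTT assay, with a stated time of 72 h; on this read-out higher numbers stand for weaker inhibition and lower numbers for stronger inhibition
- compound 2 `CC/C=C\C(=O)Nc1cc(Nc2nccc(-c3cn(C)c4ccccc34)n2)c(OC)cc1N(C)CCN(C)C` gives 3860 nM in this assay
- compound 3 `C=C(Cl)C(=O)Nc1cc(Nc2ncc(C#N)c(-c3cn(C)c4ccccc34)n2)c(OC)cc1N(C)CCN(C)C` gives 1620 nM in this assay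

In this assay the step of a 1.3-fold higher number from compound 1 to compound 3 (0.10 log units; within the scatter) lies within the scatter, so the two compounds cannot be told apart; compound 2 gives a clearly higher number than compound 3, the gap lying beyond the scatter. Compound 4 `COc1cc(N(C)CCN(C)C)c(NC(=O)/C=C\C(C)C)cc1Nc1ncc(C#N)c(-c2cn(C)c3ccccc23)n1` has not been measured in this assay. Its difference from compound 3 is 3-methylbut-1-en-1-yl in place of 1-chloroethenyl on a carbonyl carbon; read one bond further out, ((1-chloroethenyl)carbonyl)amino becomes ((3-methylbut-1-en-1-yl)carbonyl)amino.

For the measured compounds named here, the only measured step bearing on this change is a 3.0-fold higher number from compound 1 to compound 2 (0.48 log units; beyond the scatter), where but-1-en-1-yl replaced 1-chloroethenyl on the same carbonyl carbon of the core without the cyano group. The 3-methylbut-1-en-1-yl group entering compound 4 is the same kind of replacement with one more carbon, so a step of similar size toward a higher number is expected in this assay. The cyano group itself, judged from a 1.3-fold higher number from compound 1 to compound 3 (0.10 log units; within the scatter), is not expected to shift this.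

Compound 4 is therefore estimated at 4800 nM in this assay, with a range of 2000 nM to 12000 nM, corresponding to an expected step of a 3.0-fold higher number from compound 3 to compound 4 (0.47 log units; beyond the scatter).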

Compound 4, half-maximal inhibitory concentration: 1110 nM
Estimate against measurement, compound 4: 4.3-fold (0.64 log units) above; the whole stated range lies above it.
By their numbers in this assay, from the lowest: compounds 4, 1 and 3 (each within the scatter of the next); then compound 2.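

In this assay the step of a 1.5-fold lower number from compound 3 to compound 4 (0.16 log units; within the scatter) leaves the two compounds indistinguishable, so on the core carrying the cyano group, 3-methylbut-1-en-1-yl can stand in place of 1-chloroethenyl on the carbonyl carbon with no readable change. The earlier step of a 3.0-fold higher number from compound 1 to compound 2 (0.48 log units; beyond the scatter) on the core without the cyano group lay beyond the scatter, so replacing 1-chloroethenyl on this carbonyl carbon does not give a step of one fixed size across the two pairs shown, and on the cyano-bearing core the 1-chloroethenyl group is not needed for a value in this range. Nothing shown gives a reason for this result.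

The two steps differ both in the entering chain and in the presence of the cyano group, so these pairs do not separate the two changes. Also open, on these data alone, is how a plain ethenyl group, or a but-1-en-1-yl chain ending in a dimethylamino group, would read on this carbonyl carbon on either core.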